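Replacing Ethylcarbamoyl with Methoxymethyl: Expected Cytotoxicity Shift

The source may report more compounds than this note shows. Statements on the series, on what has been measured and on what is new or still open speak of the compounds shown alone.

Of the compounds shown here, three sharing one core have so far been measured in an ADME assay on TZM cells (Homo sapiens) for cytotoxicity, with a stated time of 1 days; on this read-out higher numbers stand for lower toxicity in this test and lower numbers for higher toxicity in this test. Compound 1 `CCNC(=O)c1cc(N)c(Nc2ccc(C#N)cc2)cc1Oc1c(C)cc(CCC#N)cc1C` gives 105000 nM, the highest of the three numbers. Compound 2 `CC(=O)OCc1cc(N)c(Nc2ccc(C#N)cc2)cc1Oc1c(C)cc(CCC#N)cc1C` gives 44800 nM, and compound 3 `Cc1cc(CCC#N)cc(C)c1Oc1cc(Nc2ccc(C#N)cc2)c(N)cc1COC(=O)C1CC1` gives 42200 nM. Each measured step away from compound 1 removes the ethylcarbamoyl group: a 2.3-fold lower number from compound 1 to compound 2 (0.37 log units; beyond the scatter), and a 2.5-fold lower number from compound 1 to compound 3 (0.40 log units; beyond the scatter). Between the two replacements themselves the difference is small, a 1.1-fold lower number from compound 2 to compound 3 (0.03 log units; within the scatter).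

Compound 4 `COCc1cc(N)c(Nc2ccc(C#N)cc2)cc1Oc1c(C)cc(CCC#N)cc1C` has not yet been measured. It differs from compound 1 in one place: methoxymethyl in place of ethylcarbamoyl on an aromatic carbon. Like the two measured steps, this change removes the ethylcarbamoyl group, so the steps from compound 1 to compound 2 and from compound 1 to compound 3 are the ones that bear on it; both were modest and both ran toward a lower number. The group entering here is not one that appears in the measured set, so the expectation rests on the direction those two steps share rather than on a close match. Compound 4 is therefore expected to show a modest step down in this assay, a 1.9-fold lower number from compound 1 to compound 4 (0.28 log units; within the scatter). The estimate for compound 4 is 55000 nM, with a range from 25000 nM to 120000 nM.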

Compound 4, half-maximal cytotoxic concentration in the TZM assay: > 200000 nM
Compound 4: a limit, no number; the forecaster's own chance of this, stated with the estimate: 15%; at least 3.6-fold (0.56 log units) between middle value and limit.
By their numbers in the TZM assay, from the lowest: compounds 3 and 2 (each within the scatter of the next); then compound 1. At a limit, above all of these: compound 4.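

In the TZM assay compound 4 gives > 200000 nM, which is a limit of the assay and not a number. In the TZM assay the methoxymethyl group on this aromatic carbon gives an at least 1.9-fold higher number from compound 1 to compound 4 (0.27 log units; that floor lies within the scatter), and the acetyl and cyclopropylcarbonyl groups on the oxygen compare with methyl as an at least 4.4-fold higher number from compound 2 to compound 4 (0.64 log units; beyond the scatter) and an at least 4.7-fold higher number from compound 3 to compound 4 (0.67 log units; beyond the scatter), so the lower numbers of compound 2 and compound 3 go with those two groups rather than with the loss of ethylcarbamoyl alone. In a physicochemical assay for solubility, read by HPLC, with a stated time of 4 h, at pH 2, tested at 10 mg/mL (on this read-out lower numbers stand for lower solubility and higher numbers for higher solubility), compound 1 gives 69.4 ug/mL and compound 4 gives 1.82 ug/mL. The same change from ethylcarbamoyl to methoxymethyl also comes with a large fall in the physicochemical assay: the measured solubility of compound 1, 69.4 ug/mL, and of compound 4, 1.82 ug/mL, a 38-fold lower number (1.58 log units; beyond the scatter)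

As far as these compounds go, with compound 4 at a limit, how far its number lies above that of compound 1 stays unknown, and the floor of that step, which lies within the scatter, cannot settle whether the two truly differ. Also open, from the compounds shown here alone, is whether a hydroxymethyl group, an aminomethyl group or a longer ether chain such as ethoxymethyl on this aromatic carbon would stand with compound 4 or with compound 2 and compound 3.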